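Isopropoxy gives way to methyl on a carbonyl carbon

The compounds below may be only part of what the source reports. "The series", "measured", "known", "first", "only" and "open" are said of these compounds alone.

Measured so far in an ADME assay on HEK-293T cells (Homo sapiens) for cytotoxicity, read by MTT assay, with a stated time of 3 days; on this read-out higher numbers stand for lower toxicity in this test and lower numbers for higher toxicity in this test:
compound 1 `CC(C)OC(=O)COC(=O)c1ccc([N+](=O)[O-])o1` gives > 100000 nM
compound 2 `CC(=O)Oc1ccc(CN(C(=O)COC(=O)c2ccc([N+](=O)[O-])o2)C(C)(C)C)cc1` gives > 100000 nM

Compound 1 stands at > 100000 nM as a limit of the assay and not as a number. Compound 2 gives > 100000 nM as a limit too. The evidence so far is the limit of > 100000 nM in this assay, at which 2 of the 2 values shown sit, and nothing finer.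

Compound 3 `CC(=O)COC(=O)c1ccc([N+](=O)[O-])o1` has yet to be measured. It differs from compound 1 by methyl in place of isopropoxy on a carbonyl carbon in one place, with methyl in place of isopropoxy on a carbonyl carbon. For the measured compounds named here, no step between measured compounds is available to size this change. In this assay no step beyond the scatter is expected, and no direction is favoured, since compound 1 rests at > 100000 nM as a limit and gives no number to move from. The expected change is a number no higher from compound 1 to compound 3 (the limit leaves the size open) and no more. Compound 3 is estimated at 100000 nM with 40000 nM to 200000 nM as the expected range.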

Compound 3, half-maximal cytotoxic concentration: > 100000 nM
Compound 3: a limit, no number; the forecaster's own chance of this, stated with the estimate: 75%; the middle value sits exactly at the limit.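

Compound 3, like compound 1, ends at a limit of this assay and not at a number, so no step can be read between these two compounds. The compounds shown leave open what concentration, if any, would harm these cells, because all of them share one ceiling: the limit of > 100000 nM in this assay, at which 3 of the 3 values shown sit.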